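The compounds below may be only part of what the source reports. "The series", "measured", "known", "first", "only" and "open" are said of these compounds alone.

In a physicochemical assay for lipophilicity, using the shake flask method (on this read-out lower numbers stand for lower lipophilicity and higher numbers for higher lipophilicity), compound 1 `C[C@H](Oc1ccc(NC(=O)CC(=O)O)c(C2CC2)c1)c1c(Cl)ccc(F)c1Cl` gives 1.9 and is the lower of the two measured compounds, while compound 2 `Cc1c(/C=C/C(=O)O)cnc2ccc(O[C@@H](C)c3c(Cl)ccc(F)c3Cl)cc12` gives 3 on the same scale. Compound 3 `C[C@H](Oc1ccc(NC(=O)CC(N)=O)c(C2CC2)c1)c1c(Cl)ccc(F)c1Cl` has amino in place of hydroxy on a carbonyl carbon, so the carboxy of compound 1 becomes carbamoyl (amino in place of hydroxy on a carbonyl carbon). For the measured compounds named here, no measured pair shows this change, so its size is a judgement: a clear rise in this assay beyond the scatter is expected, with a number 1.60 log units higher from compound 1 to compound 3 (beyond the scatter) as the estimated step. The estimated value for compound 3 is 3.5 within an expected range of 2.9 to 4.1 in this measurement.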

Compound 3, distribution coefficient: 3.9
Estimate against measurement, compound 3: 0.40 log units below, within the range that was stated.
By their numbers in this assay, from the lowest: compound 1; then compound 2; then compound 3.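

In this assay the change from carboxy to carbamoyl at this position gives a number 2.00 log units higher from compound 1 to compound 3 (beyond the scatter) for the exchange of a single heavy atom, which makes it a large step. Hydroxy and amino count the same here in hydrogen-bond donors and acceptors, so these counts do not follow the step. Nothing measured here accounts for its size. Still open, as far as these compounds go, is whether a methylamino or dimethylamino group on the same carbonyl carbon would move the number as far, and whether the same change on compound 2 would give a similar step.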